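One Ring Stereocentre Flipped in a Sulfonamide Antagonist

The source may report more compounds than this note shows. Statements on the series, on what has been measured and on what is new or still open speak of the compounds shown alone.

Compound 2 `N#Cc1ccc(O[C@H]2CN(S(=O)(=O)c3ccc(Cl)cc3Cl)C[C@H]2CO)cc1F` has been tested in an assay on cells for antagonist activity at transient receptor potential cation channel subfamily V member 4 (Homo sapiens), read by FLIPR and calcium flux, with a stated time of 10 min (on this read-out higher numbers stand for weaker inhibition and lower numbers for stronger inhibition), where compound 2 gives 50 nM. Among the compounds with a single number in this assay, this is the lowest; compound 3 `N#Cc1ccc(OCC2CCN(S(=O)(=O)c3ccc(Cl)cc3Cl)CC2)cc1F` gives 6300 nM, a much weaker result, and compound 1 `N#Cc1ccc(O[C@H]2CN(S(=O)(=O)c3ccc(Cl)cc3Cl)C[C@@]2(O)CO)cc1F` is recorded twice, at 2.5 nM; 4 nM (2 entries). Compound 4 `N#Cc1ccc(O[C@H]2CN(S(=O)(=O)c3ccc(Cl)cc3Cl)C[C@@H]2CO)cc1F` has not yet been measured; compared with compound 2, (the two compounds have the same atoms and bonds and differ only in configuration as drawn: 1 of 2 stereo elements differ; a stereocentre at a saturated ring carbon is drawn S in compound 2 and R in compound 4). Within the data shown here, no measured pair differing in a single place exists here, so the size of such a change cannot be read from the data. The step to compound 4 is nonetheless expected to weaken inhibition by a clear margin, beyond the usual scatter. For compound 4 a value of 400 nM is estimated, with a range from 40 nM to 4000 nM, meaning an expected step of an 8.0-fold higher number from compound 2 to compound 4 (0.90 log units; beyond the scatter).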

Compound 4, half-maximal inhibitory concentration: 200 nM
Estimate against measurement, compound 4: 2.0-fold (0.30 log units) above; measured number inside the range.
By their numbers in this assay, from the lowest: compound 2; then compound 4; then compound 3.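

Flipping a single stereocentre at a saturated ring carbon gives a 4.0-fold higher number from compound 2 to compound 4 (0.60 log units; beyond the scatter) in this assay. Among these compounds, this is the first measured change in a single place here, and it shows that this carbon's configuration matters even though the step is modest. The step can be tied to configuration alone because no atom or bond changes: the fact that compounds 2 and 4 differ only in the configuration as drawn

Going by these compounds, it remains open whether the flip would have a similar effect in compound 1. On these data alone, it is also open how an amine or a carboxylic acid on this carbon would fare in either configuration.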